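This account rests on a few compounds, and the source may have more. Where it says the series, first, only, none or still open, it means among the compounds named here.

The account follows compound 2 `O=c1[nH]c2ccccc2n1CCN1CCN(c2ccccc2)CC1` and its unmeasured analogue compound 3 `COc1cccc(-n2c(=O)n(CCN3CCN(c4ccccc4)CC3)c3ccccc32)c1`. Among the compounds with values here, in an assay on HEK293 cells for displacement of a labelled ligand from 5-hydroxytryptamine receptor 7 (Homo sapiens) (a higher number here means a weaker inhibitor, a lower number a stronger inhibitor), compound 2 gives 1030 nM, the highest of the two numbers so far; its nearest neighbour is compound 1 `COc1ccc(-n2c(=O)n(CCN3CCN(c4ccccc4)CC3)c3ccccc32)cc1`, which in this assay gives 566 nM, a gap that lies within the scatter. Within the data shown here, the only step measured so far, a 1.8-fold higher number from compound 1 to compound 2 (0.26 log units; within the scatter), put hydrogen in place of 4-methoxyphenyl on the aromatic nitrogen. Compound 3 runs the other way: 3-methoxyphenyl in place of hydrogen on an aromatic nitrogen. Because a 1.8-fold higher number from compound 1 to compound 2 (0.26 log units; within the scatter) stayed within the scatter, no shift beyond the scatter is expected for compound 3 in this assay either, and if anything a somewhat lower number, back toward the value of compound 1. Compound 3 is therefore expected to give about 600 nM in this assay, within a range from 250 nM to 1500 nM. This expectation amounts to a step of a 1.7-fold lower number from compound 2 to compound 3 (0.23 log units; within the scatter).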

Compound 3, inhibition constant: 864 nM
Estimate against measurement, compound 3: 1.4-fold (0.16 log units) below; low and high end bracket the measured number.
By their numbers in this assay, from the lowest: compounds 1, 3 and 2 (each within the scatter of the next).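

In this assay, 3-methoxyphenyl in place of hydrogen on the aromatic nitrogen gives a 1.2-fold lower number from compound 2 to compound 3 (0.08 log units; within the scatter), so compound 3 now joins compound 1 in showing that a methoxyphenyl group at this position stays within the scatter of hydrogen. The change from 4-methoxyphenyl to 3-methoxyphenyl gives a 1.5-fold higher number from compound 1 to compound 3 (0.18 log units; within the scatter), which shows for these two compounds that where the methoxy group stands on the phenyl ring makes no difference beyond the scatter. Nothing available offers an explanation for these results.

On these data alone, it remains open whether a group of another kind on this nitrogen, such as a methyl, an aminoethyl chain or a carboxylic acid, would shift the number beyond the scatter. Also open, as far as these compounds go, is whether a fluorine or a hydroxyl in place of the methoxy group on the phenyl ring would do so.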